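The source may report more compounds than this note shows. Statements on the series, on what has been measured and on what is new or still open speak of the compounds shown alone.

Compound 3 `CC1(C)Oc2ccc(C#N)cc2[C@H](N(Cc2ccco2)c2ccccc2)[C@H]1O` is the least potent of the two compounds that returned a number in a functional assay (aorta) with Rattus norvegicus as the target; on this read-out higher numbers stand for weaker inhibition and lower numbers for stronger inhibition: compound 3 gives 12000 nM. Its nearest neighbour is compound 2 `CCOC(=O)NN(c1ccccc1)[C@H]1c2cc(C#N)ccc2OC(C)(C)[C@@H]1O`, which in this assay gives 2200 nM, and the step of a 5.5-fold higher number from compound 2 to compound 3 (0.74 log units; beyond the scatter) runs against compound 3. Compound 1 `CC1(C)Oc2ccc(C#N)cc2[C@H](N(CC(=O)O)c2ccccc2)[C@H]1O` returned only a limit, > 100000 nM, in this assay, and this is the limit described under (the limit of > 100000 nM in this assay, at which 1 of the 3 values shown sits).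

The next compound, compound 4 `Cc1noc(CN(c2ccccc2)[C@H]2c3cc(C#N)ccc3OC(C)(C)[C@@H]2O)n1`, differs from compound 3 by one change: 3-methyl-1,2,4-oxadiazol-5-yl in place of furan-2-yl on a saturated chain carbon bound to a nitrogen on an aromatic ring. For the measured compounds named here, no measured step exchanges one five-membered aromatic ring for another at this position. The closest measured step is an at least 8.3-fold lower number from compound 1 to compound 3 (0.92 log units; beyond the scatter), where the furan-2-yl entered in place of carboxy at the same saturated chain carbon and brought an at least modest gain, and a 5.5-fold higher number from compound 2 to compound 3 (0.74 log units; beyond the scatter), which shows that the whole group on that nitrogen moves the read-out by modest amounts. Since the furan-2-yl itself is retained in spirit as a small heteroaromatic ring, only a change within the scatter, or at most a modest one, is expected in this assay, with the direction uncertain. The expected step is a 1.2-fold lower number from compound 3 to compound 4 (0.08 log units; within the scatter). Compound 4 is therefore estimated at 10000 nM, with a range from 3000 nM to 40000 nM.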

Compound 4, half-maximal inhibitory concentration: > 30000 nM
Compound 4 ended at the assay's limit; the forecaster's own chance of this, stated with the estimate: 10%; middle value at least 3.0-fold (0.47 log units) from the limit.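

For the compounds shown here, the exchange of furan-2-yl for 3-methyl-1,2,4-oxadiazol-5-yl on a saturated chain carbon bound to a nitrogen on an aromatic ring is the first measured swap of one five-membered aromatic ring for another here, and it is not neutral in this assay: it gives an at least 2.5-fold higher number from compound 3 to compound 4 (0.39 log units; beyond the scatter), so the identity of the ring matters at this position, not just the presence of one. Compound 4 gives a limit rather than a number, so the full size of this step stays unknown: the limit of > 30000 nM in this assay, at which 1 of the 4 values shown sits.

Against the group on the nitrogen in compound 2, the change gives an at least 13-fold higher number from compound 2 to compound 4 (1.13 log units; beyond the scatter), which leaves the (ethoxycarbonyl)amino of compound 2 with the lowest number of the four, while the step between compound 1 and compound 4 cannot be read, as both are limits.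

The entering ring differs from furan-2-yl both in its methyl and in its hetero atoms, and the compounds shown do not separate the two. From the compounds shown here alone, it also stays open how a 1,2,4-oxadiazol-5-yl without the methyl, a thiophen-2-yl or a longer chain carrying the ring would read in this assay.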